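Trimming the saturated chain of compound 1

A few compounds are considered here, and "the series" means these few. Any claim that something is new, unique, unknown or untested is made for them only; others in the source may bear on it.

Among the measured compounds shown here, in an ADME assay on CHO-K1 cells (Cricetulus griseus) for cytotoxicity, read by MTT assay, with a stated time of 24 h (on this read-out lower numbers stand for stronger inhibition and higher numbers for weaker inhibition), compound 1 (`CCCCCCCCCCCC(=O)Nc1nnc(S[C@@H]2O[C@H](COC(C)=O)[C@H](OC(C)=O)[C@H](OC(C)=O)[C@H]2OC(C)=O)s1`) gives 27700 nM as the only number so far. Compound 2 (`CCCCCCCC/C=C\CCCCCCCC(=O)Nc1nnc(S[C@@H]2O[C@H](CO)[C@H](O)[C@H](O)[C@H]2O)s1`) stands as "not active" (no number reported) with no number reported. Compound 3 (`CCCCCCCCCC(=O)Nc1nnc(S[C@@H]2O[C@H](COC(C)=O)[C@H](OC(C)=O)[C@H](OC(C)=O)[C@H]2OC(C)=O)s1`) carries hydrogen in place of ethyl on a saturated chain carbon, nine bonds along the chain from a carbonyl carbon. For the measured compounds named here, no measured step exists yet, so in this assay only a small move towards weaker inhibition, hardly beyond the scatter, is expected (a 1.3-fold higher number from compound 1 to compound 3 (0.10 log units; within the scatter)). Compound 3 is estimated at 35000 nM (range 15000 nM to 90000 nM).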

Compound 3, half-maximal inhibitory concentration: 19400 nM
Beside the measured number, compound 3's estimate is 1.8-fold (0.26 log units) above it, within the range that was stated.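

In this assay, hydrogen in place of ethyl on a saturated chain carbon, nine bonds along the chain from a carbonyl carbon, gives a 1.4-fold lower number from compound 1 to compound 3 (0.15 log units; within the scatter) and so stays inside the usual scatter. This position therefore tolerates this shortening of the saturated chain with no readable change in the cytotoxicity read-out. No available evidence bears on this result. Open, as far as these compounds go, is whether a longer chain, or a carboxylic acid or an amine at the chain end, would give a step beyond the scatter.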